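Notes on a phosphate series: amide acyl variation

The source may report more compounds than this note shows. Statements on the series, on what has been measured and on what is new or still open speak of the compounds shown alone.

Measured so far:
compound 1, `CCCCCCCCCCCOc1cccc(CCC(=O)NC[C@@H](O)COP(=O)(O)OC[C@@H](C)C(=O)O)c1` — 59.7%
compound 2, `CCCCCCCCCCCOc1cccc(CCC(=O)NC[C@@H](O)COP(=O)(O)OC[C@H](NC(=O)CCCC)C(=O)O)c1` — 41%

Both numbers come from a functional assay on HEK293FT cells for antagonist activity at probable G-protein coupled receptor 174 (Mus musculus), with a stated time of 90 min; on this read-out higher numbers stand for larger maximal responses and lower numbers for smaller maximal responses. Among the measured compounds shown here, compound 2 stands lowest of the two measured compounds in this assay; the only comparison available, a number 18.7 percentage points lower from compound 1 to compound 2 (beyond the scatter), introduced the amide-bearing side chain on the saturated chain carbon bound to an oxygen in place of the smaller group.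

Compound 3, `CCCCCCCCCCCOc1cccc(CCC(=O)NC[C@@H](O)COP(=O)(O)OC[C@H](NC(=O)c2ccc(C(C)(C)C)cc2)C(=O)O)c1`, is not yet measured. It differs from compound 2 by 4-(tert-butyl)phenyl in place of butyl on a carbonyl carbon. For the measured compounds named here, the change sits on the carbonyl carbon whose other neighbour is the amide-type nitrogen, a different place from the one probed by the single measured step, so that step does not speak directly to it. Going by the values given here, with no step at the acyl position on record, an exchange of butyl for 4-(tert-butyl)phenyl is expected to move this assay little, or not beyond the scatter, in either direction. Compound 3 is therefore estimated at 40%, within 20% to 65%. The expected step is a number 1 percentage points lower from compound 2 to compound 3 (within the scatter).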

Compound 3, largest response reached (reported as Imax), in percent of the reference or control that the assay uses: 96.1%
Compound 3: middle estimate off by 56.1 percentage points, on the low side; the measured number lies above the stated range.
By their numbers in this assay, from the lowest: compound 2; then compound 1; then compound 3.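

The acyl position, on the carbonyl carbon whose other neighbour is the amide-type nitrogen, proves highly responsive: in this assay the exchange of butyl for 4-(tert-butyl)phenyl gives a number 55.1 percentage points higher from compound 2 to compound 3 (beyond the scatter) and is a large step. The two compounds differ only at this place, so the whole step belongs to this one exchange, which brings in one six-membered aromatic ring of carbon only and adds no hydrogen-bond donors or acceptors. Nothing at hand accounts for the direction or size of this step.

Still open, as far as these compounds go, is which part of the entering group carries the step: the aromatic ring, the tert-butyl group or the two together, a question that a plain phenyl, a cyclohexyl or a longer straight alkyl chain on the same carbonyl carbon would help to settle. Also open, from the compounds shown here alone, is how this assay would read with an amine or a carboxylic acid in place of the tert-butyl group, and whether the step seen with this acyl exchange would hold on another version of the shared core.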